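This account rests on a few compounds, and the source may have more. Where it says the series, first, only, none or still open, it means among the compounds named here.

Measured compounds:
- compound 1, `CCO/N=C(/c1ccc(Br)cc1)C1CCN(C(C)CCNC(=O)c2c(Cl)cncc2Cl)CC1`, with 33800 nM
- compound 2, `CC(CCNC(=O)c1c(Cl)cncc1Cl)N1CCC(C(Oc2cccc(C(=O)O)n2)c2ccc(C(F)(F)F)cc2)CC1`, with 28700 nM

Both numbers come from an ADME assay on PBMC cells (Homo sapiens) for cytotoxicity; on this read-out lower numbers stand for higher toxicity in this test and higher numbers for lower toxicity in this test. Within the data shown here, compound 2 has the lower of the two numbers, but its nearest neighbour, compound 1, sits within the usual scatter of this assay, so the two compounds cannot be told apart on toxicity from these data; nothing is known yet about how a change in structure moves the number, as no pair of measured compounds differs in only one place.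

The next compound, compound 3 `CC(CCNC(=O)c1c(Cl)cncc1Cl)N1CCC(C(Oc2ccccc2C(F)(F)F)c2ccc(C(F)(F)F)cc2)CC1`, is built from compound 2 by a single change: 2-(trifluoromethyl)phenyl in place of 6-carboxypyridin-2-yl on an oxygen on a saturated carbon. The group that leaves carries a hydrogen-bond donor and two acceptors; the group that enters carries none of either, so the change is sizeable in kind. Among the measured compounds shown here, with no measured step of this type to lean on, the direction is uncertain, but a step beyond the scatter in this assay seems more likely than none, toward a lower number.

On that basis, compound 3 is estimated at 15000 nM, within a range of 5000 nM to 40000 nM, which would mean an expected step of a 1.9-fold lower number from compound 2 to compound 3 (0.28 log units; within the scatter).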

Compound 3, half-maximal cytotoxic concentration: 12500 nM
The estimate for compound 3 lay 1.2-fold (0.08 log units) above the measured number; low and high end bracket the measured number.
By their numbers in this assay, from the lowest: compound 3; then compounds 2 and 1 (each within the scatter of the next).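

Among these compounds, this is the first pair of measured compounds that differ in only one place, and it shows that the group on this oxygen can move the number in this assay: putting 2-(trifluoromethyl)phenyl in place of 6-carboxypyridin-2-yl gives a 2.3-fold lower number from compound 2 to compound 3 (0.36 log units; beyond the scatter), which stands for higher toxicity in this test. The step is modest, but unlike the gap between compound 1 and compound 2, it lies beyond the usual scatter, so this position does register in the read-out. The change removes the carboxylic acid and the ring nitrogen and adds trifluoromethyl all at once, and no evidence here bears on why the number falls.

Telling these parts apart would take groups in between on the same oxygen, such as a plain phenyl, a pyridin-2-yl without the acid, or a methyl ester in place of the acid. On these data alone, it also remains open whether other groups at this position, such as an amine, would move the number further in either direction.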